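Trifluoromethyl in Place of Methyl on the Aryloxy Ring

The compounds below may be only part of what the source reports. "The series", "measured", "known", "first", "only" and "open" are said of these compounds alone.

For the measured compounds named here, compound 1 `Cc1cccc(OCC(=O)Nc2ccc(OCC(=O)O)c(F)c2)c1` gives the higher of the two numbers so far in a functional assay on CHO cells for agonist activity at Free fatty acid receptor 1 (Homo sapiens), read by FLIPR, tested at 100 nM (on this read-out lower numbers stand for a weaker effect and higher numbers for a stronger effect at the one concentration tested), at 45.4%. Going by the values given here, compound 2 `Cc1ccc(OCC(=O)Nc2ccc(OCC(=O)O)c(F)c2)cc1` gives 31.2%, and the single measured step, a number 14.2 percentage points lower from compound 1 to compound 2 (beyond the scatter), concerns a shift of the methyl rather than its replacement. Compound 3 `O=C(O)COc1ccc(NC(=O)COc2cccc(C(F)(F)F)c2)cc1F` differs from compound 1 by trifluoromethyl in place of methyl on an aromatic carbon. Among the compounds with values here, no measured step bears directly on this exchange, so the data give no direction for it. The step of a number 2.6 percentage points higher from compound 1 to compound 3 (within the scatter) is expected to stay within the scatter. The estimate for compound 3 in this assay is 48%, between 25% and 70%.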

Compound 3, a percentage reported as activity, at one concentration (the size of the read-out at that concentration, not a potency): 11.4%
Compound 3: middle estimate off by 36.6 percentage points, on the high side; the whole stated range lies above it.
By their numbers in this assay, from the lowest: compound 3; then compound 2; then compound 1.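

In this assay the step of a number 34 percentage points lower from compound 1 to compound 3 (beyond the scatter) shows that this aromatic carbon, meta to a large group, does not tolerate every exchange of its substituent. For the compounds shown here, the earlier compounds showed only that moving the methyl changes the number, whereas here the methyl stays in place and is replaced by trifluoromethyl. Nothing available explains this drop. From the compounds shown here alone, whether chlorine or methoxy on this carbon would give a similar loss remains open. So does how trifluoromethyl would behave at the ring position that carries the methyl in compound 2.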